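Furanylmethylthio in place of alkoxy on a carbamate carbonyl

A few compounds are considered here, and "the series" means these few. Any claim that something is new, unique, unknown or untested is made for them only; others in the source may bear on it.

Compound 1 `CC(C)c1cccc(C(C)C)c1OC(=O)NC(=O)OCc1ccccc1`: 77 nM
Compound 2 `CCCCCCCCOC(=O)NC(=O)Oc1c(C(C)C)cccc1C(C)C`: 250 nM
Compound 3 `CCCCC(C)(C)OC(=O)NC(=O)Oc1c(C(C)C)cccc1C(C)C`: 64 nM

These three compounds were tested in an assay on microsomes from intestine for inhibition of acyl-CoA:cholesterol acyltransferase (Oryctolagus cuniculus); a lower number here means a stronger inhibitor, a higher number a weaker inhibitor. Compound 3 gives the lowest of the three numbers; compound 1 sits within the scatter of it, while compound 2 is separated from it by a 3.9-fold lower number from compound 2 to compound 3 (0.59 log units; beyond the scatter). The other step beyond the scatter is a 3.2-fold higher number from compound 1 to compound 2 (0.51 log units; beyond the scatter), and a 1.2-fold lower number from compound 1 to compound 3 (0.08 log units; within the scatter) is not beyond it.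

Compound 4 `CC(C)c1cccc(C(C)C)c1OC(=O)NC(=O)SCc1ccco1` differs from compound 3 in that (a group of 7 heavy atoms (5 carbon, 1 oxygen, 1 sulfur; one five-membered aromatic ring with 1 hetero atom) in place of a group of 8 heavy atoms (7 carbon, 1 oxygen; no ring), on a carbonyl carbon). The measured steps all vary the group on the oxygen side of that carbonyl: a phenyl-bearing chain and a branched chain give numbers within the scatter of one another, and a straight chain gives a modestly higher number. None of them exchanges the oxygen for sulfur or introduces a five-membered aromatic ring, so the record gives no direct guidance on that part of the change.

Because compound 1, with an aromatic ring on this side, gives 77 nM, compound 4 is expected to stay near compound 3, with a step of a 1.6-fold higher number from compound 3 to compound 4 (0.19 log units; within the scatter) in this assay. The estimate for compound 4 is 100 nM, within a range from 30 nM to 400 nM.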

Compound 4, half-maximal inhibitory concentration: 470 nM
Estimate against measurement, compound 4: 4.7-fold (0.67 log units) below, and the stated range ends below it.
By their numbers in this assay, from the lowest: compounds 3 and 1 (each within the scatter of the next); then compounds 2 and 4 (each within the scatter of the next).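

In this assay, the ((furan-2-yl)methyl)sulfanyl group on the carbonyl carbon gives up the level held by the two best groups so far, with a 7.3-fold higher number from compound 3 to compound 4 (0.87 log units; beyond the scatter) and a 6.1-fold higher number from compound 1 to compound 4 (0.79 log units; beyond the scatter), so this position does respond to a change that keeps a ring on the carbonyl side. The benzyloxy group had matched the branched chain of compound 3, but a ring in this group is clearly not enough on its own to hold that level: with a 1.9-fold higher number from compound 2 to compound 4 (0.27 log units; within the scatter), compound 4 instead cannot be told apart from the straight-chain octyloxy compound. No measurement offered here explains the loss.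

The compounds shown leave open whether the sulfur or the furan ring accounts for the step, a question that a (furan-2-yl)methoxy group or a benzylsulfanyl group on the same carbonyl carbon would address. Also open, going by these compounds, is how a thiophene ring or a sulfur-linked 1,1-dimethylpentyl group would fare in this place.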